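Hydrazone aryl swap on a shared diaryl ether urea core

This account rests on a few compounds, and the source may have more. Where it says the series, first, only, none or still open, it means among the compounds named here.

Measured compounds:
Compound 1 `COc1ccc(/C=N/NC(=O)Nc2ccc(Oc3ccnc(-c4nncn4CCN(C)C)c3)c(F)c2)c(OC)c1OC` gives 3970 nM in a functional assay on HT-29 cells (Homo sapiens) for cytotoxicity, read by MTT assay, with a stated time of 72 h; on this read-out lower numbers stand for stronger inhibition and higher numbers for weaker inhibition.
Compound 2 `Cn1ncnc1-c1cc(Oc2ccc(NC(=O)N/N=C/c3ccccc3)cc2F)ccn1` gives 30200 nM in this assay.

Among the measured compounds shown here, of the two numbers in hand, compound 1 stands lowest; the only other compound, compound 2, returns a number beyond the scatter of compound 1, and since the two differ in more than one place, their values are all that can be said of that pair.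

The unmeasured compound 3 `CN(C)CCn1cnnc1-c1cc(Oc2ccc(NC(=O)N/N=C/c3c(O)ccc4ccccc34)cc2F)ccn1` keeps the whole of compound 1 apart from one change: 2-hydroxynaphthalen-1-yl in place of 2,3,4-trimethoxyphenyl on a carbon with a double bond to nitrogen. For the measured compounds named here, no step between measured compounds isolates such a swap, so there is no direct precedent here. The expectation for compound 3 is therefore anchored on the value of compound 1, and the step of a 1.3-fold lower number from compound 1 to compound 3 (0.12 log units; within the scatter) is estimated to be no larger than the usual scatter, if anything leaning toward a lower number. Compound 3 is expected to give about 3000 nM in this assay, with a plausible range from 700 nM to 12000 nM.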

Compound 3, half-maximal inhibitory concentration: 670 nM
Compound 3: the middle estimate sits 4.5-fold (0.65 log units) above what was measured; measured number below the stated range.
By their numbers in this assay, from the lowest: compound 3; then compound 1; then compound 2.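

Among the compounds shown here, compound 3 gives the first reading of this position with the rest of the molecule held fixed. Compound 1 and compound 2 differ in more than one place. In this assay, replacing 2,3,4-trimethoxyphenyl with 2-hydroxynaphthalen-1-yl on the carbon with a double bond to nitrogen gives a 5.9-fold lower number from compound 1 to compound 3 (0.77 log units; beyond the scatter), so a change at this one place is enough to move the number beyond the scatter, and the entering group need not be a methoxy-substituted phenyl for the compound to stay active. The swap brings in a second six-membered aromatic ring of carbon only and a hydrogen-bond donor while removing the three methoxy groups, and nothing measured here ties the lower number to any one of these differences.

On these data alone, what remains open is whether the hydroxyl group or the second ring accounts for the step, which a plain naphthalen-1-yl group or a 2-hydroxyphenyl group at the same place would begin to separate. As far as these compounds go, it is equally open how far this position tolerates other kinds of substituent, such as an amine or a carboxylic acid on the aromatic ring.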